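A few compounds are considered here, and "the series" means these few. Any claim that something is new, unique, unknown or untested is made for them only; others in the source may bear on it.

Measured so far:

- compound 1, `Cc1ccc2oc(/C=C/[S+](C)[O-])cc(=O)c2c1`: 7000 nM
- compound 2, `Cc1cccc2oc(/C=C/[S+](C)[O-])cc(=O)c12`: 5500 nM

Both compounds were tested in a functional assay on DLD-1 cells (Homo sapiens) for cytotoxicity, with a stated time of 48 h; a higher number here means a weaker inhibitor, a lower number a stronger inhibitor. Compound 1 stands at the top of the two numbers shown, and in this assay compound 1 gives 7000 nM. Its nearest neighbour is compound 2, which in this assay gives 5500 nM; the gap between the two lies within the usual scatter of repeated measurements, so the two cannot be told apart on these numbers, and neither can be called the stronger inhibitor.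

The next compound, compound 3 `CCCOc1ccc2oc(/C=C/[S+](C)[O-])cc(=O)c2c1`, has not yet been measured in this assay. Compared with compound 1 it carries one change: propoxy in place of methyl on an aromatic carbon. Within the data shown here, no pair of measured compounds shows what such a change does to the numbers in this assay, so there is no measured step to lean on. With only this to go on, the change from compound 1 to compound 3 is expected to make a step of no more than the usual scatter in either direction, a 1.2-fold lower number from compound 1 to compound 3 (0.07 log units; within the scatter). Compound 3 is therefore estimated to give 6000 nM in this assay, within a range from 2000 nM to 18000 nM.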

Compound 3, half-maximal inhibitory concentration: 6200 nM
The estimate for compound 3 lay 1.0-fold (0.01 log units) below the measured number; measured number inside the range.
By their numbers in this assay, from the lowest: compounds 2, 3 and 1 (each within the scatter of the next).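

In this assay, among these compounds, putting propoxy in place of methyl on this aromatic carbon gives a 1.1-fold lower number from compound 1 to compound 3 (0.05 log units; within the scatter) and so provides the first measured step at this position. The position can therefore carry propoxy, with its 4 heavy atoms and 1 hydrogen-bond acceptor, instead of methyl, with its 1 heavy atom and no acceptor, and the result cannot be told apart from that of compound 1 in these cells. Nothing measured here explains why the swap leaves the number within the scatter.

A single step cannot show whether this position accepts groups of every kind, since an amine, a carboxylic acid or a chain longer than propoxy could give a very different number on the same carbon. On these data alone, it also remains open whether any group at this position can move the number beyond the scatter, and whether propoxy would give the same result on the shared core in other cell types.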